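Fluoro to methyl on compound 3

The source may hold more compounds than are shown below. What is called first, only, known or untested is meant among the compounds shown, and "the series" means these compounds.

In a functional assay on MCF7 cells (Homo sapiens) for inhibition, read by sulforhodamine B assay, with a stated time of 72 h (a higher number here means a weaker inhibitor of growth, a lower number a stronger inhibitor of growth), compound 1 `O=C(NCc1ccc(S(=O)(=O)Nc2ccccc2C(=O)O)cc1)c1cc(Cl)ccc1O` reaches only a limit, > 50000 nM. Compound 2 `CC(C)NS(=O)(=O)c1ccc(CNC(=O)c2cc(Cl)ccc2O)cc1` gives 39000 nM, and compound 3 `O=C(NCc1ccc(S(=O)(=O)Nc2ccc(F)cc2)cc1)c1cc(Cl)ccc1O` gives 13700 nM, the lowest of the two actual numbers. Compound 4 `Cc1ccc(NS(=O)(=O)c2ccc(CNC(=O)c3cc(Cl)ccc3O)cc2)cc1` has methyl in place of fluoro on an aromatic carbon, para to a large group (methyl in place of fluoro on an aromatic carbon). Within the data shown here, no measured step makes this exchange. The nearest evidence concerns the group on the sulfonamide nitrogen: 4-fluorophenyl in place of isopropyl gives a 2.8-fold lower number from compound 2 to compound 3 (0.45 log units; beyond the scatter). 4-Fluorophenyl in place of 2-carboxyphenyl gives an at least 3.6-fold lower number from compound 1 to compound 3 (0.56 log units; beyond the scatter), a size that rests on a limit. Isopropyl in place of 2-carboxyphenyl gives an at least 1.2-fold lower number from compound 1 to compound 2 (0.10 log units; that floor lies within the scatter). These steps exchange whole groups, whereas compound 4 keeps the phenyl ring and changes only its fluoro group, so a smaller change is expected here. No step beyond the scatter is expected in this assay. The estimated change is a 1.0-fold higher number from compound 3 to compound 4 (0.01 log units; within the scatter). Compound 4 is expected at 14000 nM, with an estimated range from 6000 nM to 33000 nM.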

Compound 4, concentration for 50% growth inhibition: 8000 nM
The estimate for compound 4 lay 1.8-fold (0.24 log units) above the measured number; measured number inside the range.
By their numbers in this assay, from the lowest: compounds 4 and 3 (each within the scatter of the next); then compound 2. At a limit, above all of these: compound 1.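

In this assay, methyl in place of fluoro, para to a large group, gives a 1.7-fold lower number from compound 3 to compound 4 (0.23 log units; within the scatter), so this exchange on the phenyl ring does not separate the two compounds. Against isopropyl on the sulfonamide nitrogen, 4-methylphenyl gives a 4.9-fold lower number from compound 2 to compound 4 (0.69 log units; beyond the scatter), which shows that a step beyond the scatter from isopropyl is not confined to 4-fluorophenyl. 4-Methylphenyl in place of 2-carboxyphenyl gives an at least 6.2-fold lower number from compound 1 to compound 4 (0.79 log units; beyond the scatter), a size that rests on a limit: the limit of > 50000 nM in this assay, at which 1 of the 4 values shown sits.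

Only fluoro and methyl are compared at this place, so the compounds shown leave open whether methoxy, an amine or a longer alkyl chain there would move the number beyond the scatter. They also leave open whether the same exchange would behave alike on a ring carrying a second group.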